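The source may report more compounds than this note shows. Statements on the series, on what has been measured and on what is new or still open speak of the compounds shown alone.

In a physicochemical assay for lipophilicity, using the shake flask method, at pH 7.4 (on this read-out higher numbers stand for higher lipophilicity and lower numbers for lower lipophilicity), compound 1 (`CCCC(Nc1ccc(-n2cc(C(F)(F)F)cn2)nc1)c1ccc(C(=O)NCCC(=O)O)cc1`) gives 2.1 and compound 2 (`CCCC(Oc1ccc(-n2cc3ccccc3n2)cc1)c1ccc(C(=O)NCCC(=O)O)cc1`) gives 2.5 on the same scale. Compound 2 therefore holds the higher of the two numbers, and its gap to compound 1 lies beyond the usual scatter. Compound 3 (`CCCC(Oc1ccc(-n2cc(Cl)cn2)cc1)c1ccc(C(=O)NCCC(=O)O)cc1`) has not yet been measured. It departs from compound 2 by a single exchange on an aromatic carbon, para to a large group, with 4-chloro-1H-pyrazol-1-yl in place of 2H-indazol-2-yl on an aromatic carbon is the whole difference. Going by the values given here, no measured pair shows this exchange, so the expectation rests only on the structural change and on compound 2 at 2.5 as the starting point. A small fall in this assay is expected, not clearly beyond the scatter, and the estimated change is a number 0.30 log units lower from compound 2 to compound 3 (within the scatter) overall. The estimated value for compound 3 is 2.2 with an expected range from 1.8 to 2.6 in this measurement.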

Compound 3, distribution coefficient: 2.6
The estimate for compound 3 lay 0.40 log units below the measured number; low and high end bracket the measured number.
By their numbers in this assay, from the lowest: compound 1; then compounds 2 and 3 (each within the scatter of the next).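

In this assay, replacing 2H-indazol-2-yl with 4-chloro-1H-pyrazol-1-yl on an aromatic carbon, para to a large group, amounts to a number 0.10 log units higher from compound 2 to compound 3 (within the scatter). At this position, then, the entering group lacks the six-membered aromatic ring of carbon only, has 6 heavy atoms instead of 9 and carries a chlorine, yet the two compounds cannot be told apart on this read-out. No available evidence bears on the reason for this result.

The compounds shown leave open whether a nitrile or a methyl group in place of the chlorine would also stay within the scatter of compound 3. Compound 1 differs from compound 3 in more than one place, so the separate contribution of each of those differences remains unresolved.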